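A ring exchange on compound 1

A few compounds are considered here, and "the series" means these few. Any claim that something is new, unique, unknown or untested is made for them only; others in the source may bear on it.

Compound 1 `Cc1[nH]ncc1-c1nnc(-c2ccc(OC(C)C)c(Cl)c2)s1` gives 5.45 in a physicochemical assay for lipophilicity, at pH 7.4; on this read-out lower numbers stand for lower lipophilicity and higher numbers for higher lipophilicity
Compound 2 `CC(C)Oc1ccc(-c2nnc(-c3cnn(CC(=O)O)c3)s2)cc1Cl` gives 2.82
Compound 3 `Cc1c(-c2nnc(-c3ccc(OC(C)C)c(Cl)c3)s2)cnn1CCC(=O)O` gives 3.16

In this assay compound 1 stands highest of the three, with compound 3 nearest and compound 2 furthest, both beyond the scatter. Compound 4 `CC(C)Oc1ccc(-c2nnc(-c3cncn3C)s2)cc1Cl` has not yet been measured. It carries 1-methyl-1H-imidazol-5-yl in place of 5-methyl-1H-pyrazol-4-yl on an aromatic carbon. Among the measured compounds shown here, one measured step bears on this loosely: a number 2.29 log units lower from compound 1 to compound 3 (beyond the scatter), a large one, which is a different change. A moderate drop, smaller than that step, is expected (a number 0.85 log units lower from compound 1 to compound 4 (beyond the scatter)). Compound 4 is expected at 4.6 with an estimated range (3.9 to 5.3).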

Compound 4, distribution coefficient: 5.7
For compound 4 the middle estimate is 1.10 log units below the measured one; measured number outside the range, above it.
By their numbers in this assay, from the lowest: compound 2; then compound 3; then compounds 1 and 4 (each within the scatter of the next).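

The exchange of 5-methyl-1H-pyrazol-4-yl for 1-methyl-1H-imidazol-5-yl on this aromatic carbon gives a number 0.25 log units higher from compound 1 to compound 4 (within the scatter) in this assay. At this place, then, one five-membered aromatic ring with 2 hetero atoms can stand in for another, with a different count of hydrogen-bond donors and acceptors, and the two numbers stay within the scatter. No measurement shown accounts for this result.

As far as these compounds go, what remains open is whether a carboxylic acid or an amine carried on the 1-methyl-1H-imidazol-5-yl would give a step as large as a number 2.29 log units lower from compound 1 to compound 3 (beyond the scatter). The compounds shown also do not tell how a second imidazole arrangement, attached through another ring carbon, would read.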